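The source may report more compounds than this note shows. Statements on the series, on what has been measured and on what is new or still open speak of the compounds shown alone.

Measured so far in a functional assay on the whole organism (strain Swiss albino) for inhibition, with Mus musculus as the target, in the maximal electroshock model, with a stated time of 2 h, at a dose of 25 mg/kg by the intraperitoneal route; on this read-out lower numbers stand for less inhibition and higher numbers for more inhibition at the one dose given (going by the name of the read-out):
compound 1 `O=C1NC(=O)C(c2ccccc2Cl)CC1c1ccccc1Cl`: 58.3%
compound 2 `O=C1C(c2ccccc2Cl)CC(c2ccccc2Cl)C(=O)N1c1cccc(Cl)c1`: 43.7%

Compound 2 stands lowest of these two numbers. Among the compounds with values here, the one measured step, a number 14.6 percentage points lower from compound 1 to compound 2 (beyond the scatter), concerns 3-chlorophenyl in place of hydrogen on an amide-type nitrogen in a ring. Compound 3 `Cc1ccccc1N1C(=O)C(c2ccccc2Cl)CC(c2ccccc2Cl)C1=O` differs from compound 2 by 2-methylphenyl in place of 3-chlorophenyl on an amide-type nitrogen in a ring. Within the data shown here, no measured step exchanges one aryl group for another on that nitrogen, so nothing bears directly on this change, and no step beyond the scatter is expected, a number 1.3 percentage points higher from compound 2 to compound 3 (within the scatter). Compound 3 is accordingly estimated at 45%, with a range of 25% to 65%.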

Compound 3, a percentage reported as inhibition, in the whole organism at one dose (the size of the read-out at that dose, not a potency): 60.6%
Beside the measured number, compound 3's estimate is 15.6 percentage points below it; low and high end bracket the measured number.
By their numbers in this assay, from the lowest: compound 2; then compounds 1 and 3 (each within the scatter of the next).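

In this assay the choice of aryl group on the amide-type nitrogen in a ring matters: 2-methylphenyl and 3-chlorophenyl are not interchangeable there (a number 16.9 percentage points higher from compound 2 to compound 3 (beyond the scatter)). Replacing the amide hydrogen does not always lower the read-out, as 2-methylphenyl leaves it level (a number 2.3 percentage points higher from compound 1 to compound 3 (within the scatter)), unlike 3-chlorophenyl. No measurement available here accounts for the difference between these two aryl groups.

Open, from the compounds shown here alone, is whether the methyl, the chlorine or the location of each on the phenyl ring drives the step. Also open, going by these compounds, is how a benzyl group or an aminoethyl chain on that nitrogen would read.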